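Adding a methoxy group to a weak compound

The source may report more compounds than this note shows. Statements on the series, on what has been measured and on what is new or still open speak of the compounds shown alone.

Measured in a functional assay on HeLa cells (Homo sapiens) for antiproliferative activity, read by MTT assay, with a stated time of 72 h; a lower number here means a stronger inhibitor, a higher number a weaker inhibitor:
- compound 1 `Oc1ccc2ccccc2c1/C=N/NC(=S)Nc1ccccc1` gives 2000 nM
- compound 2 `NC(=S)N/N=C/c1ccccc1O` gives >= 5000 nM (a limit, not a number)
- compound 3 `CCN(CC)c1ccc(/C=N/NC(N)=S)c(O)c1` gives 2000 nM

Compound 2 has no exact number in this assay, only the limit >= 5000 nM. Compound 4 `COc1cccc(/C=N/NC(N)=S)c1O` differs from compound 2 in one place: methoxy in place of hydrogen on an aromatic carbon. In words, this is methoxy in place of hydrogen on an aromatic carbon, ortho to a hydroxy group.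

Among the compounds with values here, one measured step bears on this change. It is an at least 2.5-fold lower number from compound 2 to compound 3 (0.39 log units; beyond the scatter), which lies beyond the scatter and puts diethylamino in place of hydrogen on an aromatic carbon. This is a single example with a different group, so it suggests the direction of a change more firmly than its size. A smaller move towards a lower number therefore seems likely, and no change beyond the scatter remains possible. The expected change is an at least 1.2-fold lower number from compound 2 to compound 4 (0.09 log units; that floor lies within the scatter). For compound 4 the estimated value is 4000 nM, with an expected range from 1500 nM to 12000 nM.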

Compound 4, half-maximal inhibitory concentration: >= 5000 nM
Compound 4: no number, only a limit; the forecaster's own chance of this, stated with the estimate: 45%; at least 1.2-fold (0.09 log units) between middle value and limit.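

Neither compound 2 nor compound 4 gives an exact number, only a limit of the assay, so the step between them cannot be read: the limit of >= 5000 nM in this assay, at which 2 of the 4 values shown sit.

The compounds shown leave open whether methoxy in place of hydrogen on an aromatic carbon changes the activity at all.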